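The compounds below may be only part of what the source reports. "The series", "measured", "known", "first", "only" and "open" are said of these compounds alone.

Compound 1 `C=CCN(C)C(=O)c1ccc(C(CC)(CC)c2ccc(OCCC(O)(CC)CC)c(C)c2)n1CC`: 12800 nM
Compound 2 `CCC(C)C(NC(=O)c1ccc(C(CC)(CC)c2ccc(OCCC(O)(CC)CC)c(C)c2)n1CC)C(=O)OC`: > 50000 nM

In a functional assay on PC-3 cells (Homo sapiens) for antiproliferative activity, read by MTT assay, with a stated time of 48 h (on this read-out lower numbers stand for stronger inhibition and higher numbers for weaker inhibition), compound 1 gives 12800 nM. Compound 2 reaches only (the limit of > 50000 nM in this assay, at which 1 of the 2 values shown sits), so for it a limit rather than a number is known. Among the measured compounds shown here, the single measured step, an at least 3.9-fold higher number from compound 1 to compound 2 (0.59 log units; beyond the scatter), changed a group on the carbonyl carbon. Compound 3 `CCn1c(C(=O)NC(C)C(=O)O)ccc1C(CC)(CC)c1ccc(OCCC(O)(CC)CC)c(C)c1` differs from compound 2 at another place: a group of 5 heavy atoms (3 carbon, 2 oxygen; no ring) in place of a group of 9 heavy atoms (7 carbon, 2 oxygen; no ring), on an amide-type nitrogen. For the measured compounds named here, no measured step covers this change, and compound 2 itself offers only a limit, so size and direction cannot be read from the data. Compound 3 is therefore expected to remain weak, near 50000 nM (range 15000 nM to 150000 nM). This means an estimated step of a number no higher from compound 2 to compound 3 (the limit leaves the size open).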

Compound 3, half-maximal inhibitory concentration: 11700 nM
For compound 3 the middle estimate is 4.3-fold (0.63 log units) above the measured one; measured number outside the range, below it.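

Replacing the group of compound 2 on the amide-type nitrogen with 1-carboxyethyl gives an at least 4.2-fold lower number from compound 2 to compound 3 (0.63 log units; beyond the scatter) in this assay, so this position does respond to a change of group. The value of compound 2 is only a limit: the limit of > 50000 nM in this assay, at which 1 of the 3 values shown sits. Swapping allyl(methyl)amino for (1-carboxyethyl)amino on the carbonyl carbon gives a 1.1-fold lower number from compound 1 to compound 3 (0.04 log units; within the scatter), so these two groups cannot be told apart here. The compounds shown leave open how a methyl ester of the 1-carboxyethyl group, or a longer chain ending in a carboxylic acid, would compare.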